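The source may hold more compounds than are shown below. What is called first, only, known or untested is meant among the compounds shown, and "the series" means these compounds.

Going by the values given here, in a functional assay on MCF7 cells (Homo sapiens) for inhibition, read by MTT assay (a lower number here means a stronger inhibitor of growth, a higher number a weaker inhibitor of growth), compound 2 `COc1cc2oc(-c3cccc(NC(=O)c4ccc(Cl)cc4)c3)cc(=O)c2c(OC)c1OC` gives 8780 nM, and the only other compound measured so far, compound 1 `COc1cc2oc(-c3cccc(NC(=O)c4ccc(Br)cc4)c3)cc(=O)c2c(OC)c1OC`, gives 9650 nM. These two numbers cannot be told apart. Compound 3 `COc1cc2oc(-c3cccc(NC(=O)c4ccc(F)cc4)c3)cc(=O)c2c(OC)c1OC` changes one atom of compound 2: fluoro in place of chloro on an aromatic carbon. In words, this is fluoro in place of chloro on an aromatic carbon. Among the compounds with values here, the one measured step that bears on this is chloro in place of bromo, a 1.1-fold lower number from compound 1 to compound 2 (0.04 log units; within the scatter), which stayed within the scatter. A step no larger than the scatter, in neither direction, is therefore expected: a 1.1-fold higher number from compound 2 to compound 3 (0.03 log units; within the scatter). The estimated value for compound 3 is 9500 nM, with a range from 4500 nM to 20000 nM.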

Compound 3, concentration for 50% growth inhibition: 14700 nM
Compound 3: the middle estimate sits 1.5-fold (0.19 log units) below what was measured; measured number inside the range.
By their numbers in this assay, from the lowest: compounds 2, 1 and 3 (each within the scatter of the next).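

With fluoro now on this aromatic carbon, para to a large group, three halogens have been compared at one position in this assay, and both new steps stay within the scatter (a 1.7-fold higher number from compound 2 to compound 3 (0.22 log units; within the scatter); a 1.5-fold higher number from compound 1 to compound 3 (0.18 log units; within the scatter)). Exchanging bromo, chloro and fluoro here therefore does not separate these compounds in this assay. No measurement shown explains these numbers. Still open, as far as these compounds go, is whether a non-halogen group at this position, such as an amine or a carboxylic acid, would give a step beyond the scatter.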